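The source may hold more compounds than are shown below. What is called first, only, known or untested is meant among the compounds shown, and "the series" means these compounds.

Working notes on the series. Among the compounds with values here, in a functional assay on A375M cells (Homo sapiens) for cytotoxicity, read by MTT assay, with a stated time of 4 days (on this read-out lower numbers stand for stronger inhibition and higher numbers for weaker inhibition), compound 2 `C=C1CC(CCc2ccccc2)OC1=O` gives 8700 nM and holds the higher of the two numbers so far. Compound 1 `C=C1C(=O)OC(CCCCCCCCCCCCC)C1CC` gives 4100 nM as the lower number, and the gap between the two lies beyond the scatter. Compound 3 `C=C1C(=O)OC(CCc2ccccc2)C1CCCC` departs from compound 2 by one change (butyl in place of hydrogen on a saturated ring carbon): butyl in place of hydrogen on a saturated ring carbon. Within the data shown here, no measured pair isolates this change, and compound 1 differs from compound 2 in more than one place. Among the measured compounds shown here, compound 1 also bears a substituent on that saturated ring carbon, and its 4100 nM is the only guide available. The expected change in this assay is a 2.2-fold lower number from compound 2 to compound 3 (0.34 log units; beyond the scatter) in the direction of a lower number and near the edge of the scatter. The estimated value for compound 3 is 4000 nM with an expected range from 1500 nM to 10000 nM for a single measurement.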

Compound 3, half-maximal inhibitory concentration: 5000 nM
Estimate against measurement, compound 3: 1.3-fold (0.10 log units) below, within the range that was stated.
By their numbers in this assay, from the lowest: compounds 1, 3 and 2 (each within the scatter of the next, the first and the last beyond it).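

In this assay, butyl in place of hydrogen on a saturated ring carbon now has a measured pair of its own, and it gives a 1.7-fold lower number from compound 2 to compound 3 (0.24 log units; within the scatter). This ring carbon, two ring bonds from the ring oxygen, therefore carries a butyl group with no change that can be told from the scatter, so compound 3 and compound 2 stand level on this read-out. A single pair shows this only for butyl and only with the rest of compound 2 held fixed.

From the compounds shown here alone, it remains open whether a longer chain, an amine or a carboxylic acid on this same ring carbon would move the number beyond the scatter. Nothing available offers an explanation for the size of this step.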